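The source may hold more compounds than are shown below. What is called first, only, known or untested is meant among the compounds shown, and "the series" means these compounds.

In a functional assay on PC-3 cells (Homo sapiens) for antiproliferative activity, read by WST assay, with a stated time of 3 days (a higher number here means a weaker inhibitor, a lower number a stronger inhibitor), compound 1 `CCCOc1c(-c2cc(OC)c(OC)c(OC)c2)oc2ccccc2c1=O` gives 11800 nM, compound 2 `CCCC(C)Oc1c(-c2cc(OC)c(OC)c(OC)c2)oc2ccccc2c1=O` gives 49300 nM and compound 3 `CCN(CC)CCCCOc1c(-c2cc(OC)c(OC)c(OC)c2)oc2ccccc2c1=O` gives 13700 nM. Compound 3 therefore lies within the scatter of compound 1, and its number is clearly lower than that of compound 2.

Compound 4 `CCCN(CCC)CCCCCOc1c(-c2cc(OC)c(OC)c(OC)c2)oc2ccccc2c1=O` changes compound 3 as follows: (dipropylamino)methyl in place of diethylamino on a saturated chain carbon, four bonds along the chain from an oxygen on an aromatic ring. Within the data shown here, no measured step alters the groups on that nitrogen. Among the measured compounds shown here, the closest precedent is a 1.2-fold higher number from compound 1 to compound 3 (0.06 log units; within the scatter), which brought in the diethylamino group. The other two steps, a 4.2-fold higher number from compound 1 to compound 2 (0.62 log units; beyond the scatter) and a 3.6-fold lower number from compound 2 to compound 3 (0.56 log units; beyond the scatter), both involve the 1-methylbutyl of compound 2 and are modest.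

No step beyond the scatter is therefore expected in this assay. The expected change is a 1.4-fold lower number from compound 3 to compound 4 (0.16 log units; within the scatter). Compound 4 is estimated at 9500 nM, within an expected range of 3500 nM to 26000 nM.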

Compound 4, half-maximal inhibitory concentration: 2600 nM
For compound 4 the middle estimate is 3.7-fold (0.56 log units) above the measured one; measured number outside the range, below it.
By their numbers in this assay, from the lowest: compound 4; then compounds 1 and 3 (each within the scatter of the next); then compound 2.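

In this assay, the 5-(dipropylamino)pentyl chain gives a 5.3-fold lower number from compound 3 to compound 4 (0.72 log units; beyond the scatter), so an amine-bearing chain now moves the number beyond the scatter, which the chain of compound 3 did not do relative to compound 1. Against the plain ether chains it gives a 4.5-fold lower number from compound 1 to compound 4 (0.66 log units; beyond the scatter) and a 19-fold lower number from compound 2 to compound 4 (1.28 log units; beyond the scatter), leaving compound 4 the lowest of the four. Nothing available explains this shift.

This step lengthens the chain and changes the groups on the nitrogen together, so the compounds shown cannot separate the two, and 5-(diethylamino)pentyl or 4-(dipropylamino)butyl would bear on that. Going by these compounds, how a piperidine at the chain end compares also stays open.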